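The source may report more compounds than this note shows. Statements on the series, on what has been measured and on what is new or still open speak of the compounds shown alone.

Measured compounds in a functional assay on A549 cells (Homo sapiens) for antiproliferative activity, read by WST assay, with a stated time of 48 h; a lower number here means a stronger inhibitor, a higher number a weaker inhibitor:

compound 1, `Clc1cccc(Nc2ncnc3ccc(NCc4ccc5c(c4)OCCCCO5)cc23)c1`, 44.8 ug/mL
compound 2, `O=C(Nc1ccc2ncnc(Nc3cccc(Br)c3)c2c1)C1COc2ccccc2O1`, 73.8 ug/mL
compound 3, `O=C(Nc1ccc2ncnc(Nc3cccc(Cl)c3)c2c1)C1COc2ccccc2O1`, 61.2 ug/mL

Compounds 2 and 3 share one core, while compound 1 is built on another; the difference between the two cores is not broken down here. In this assay compound 1 gives 44.8 ug/mL and compound 3 gives 61.2 ug/mL, and these two numbers lie within the usual scatter of each other, so nothing separates them. Compound 2 gives 73.8 ug/mL, which again lies within the scatter of both other values, so no ranking among the three can be drawn.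

For the measured compounds named here, the one single-point change that was measured sits within the shared core of compounds 3 and 2: bromo in place of chloro on an aromatic carbon. This change made a step of a 1.2-fold higher number from compound 3 to compound 2 (0.08 log units; within the scatter).

Compound 4 `Brc1cccc(Nc2ncnc3ccc(NCc4ccc5c(c4)OCCCCO5)cc23)c1` has not yet been measured. It carries the same change, made on the core of compound 1 instead: bromo in place of chloro on an aromatic carbon. The place of the change is described in the same words for both pairs, so the change is the same one.

Because the step of a 1.2-fold higher number from compound 3 to compound 2 (0.08 log units; within the scatter) lay within the scatter, compound 4 is expected to give about 50 ug/mL. The range for compound 4 is estimated to run from 28 ug/mL to 90 ug/mL. This amounts to an expected step of a 1.1-fold higher number from compound 1 to compound 4 (0.05 log units; within the scatter).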

Compound 4, half-maximal inhibitory concentration: > 100 ug/mL
Compound 4 was reported as a limit (the forecaster's own chance of this, stated with the estimate: 5%); at least 2.0-fold (0.30 log units) between middle value and limit.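

In this assay compound 4 gives > 100 ug/mL, which is a limit of the assay and not a number. Read against that limit, bromo in place of chloro on an aromatic carbon makes a step of an at least 2.2-fold higher number from compound 1 to compound 4 (0.34 log units; beyond the scatter), so on the core of compound 1 this change goes with a weaker result, and the true size of the step remains unknown. The result does not show that the change acts differently on the two cores, nor that it acts alike on them, so carrying the earlier step over to this core is neither confirmed nor ruled out: the same change on two cores in this assay, a 1.2-fold higher number (0.08 log units; within the scatter) from compound 3 to compound 2 and an at least 2.2-fold higher number (0.34 log units; beyond the scatter) from compound 1 to compound 4; the limit leaves it open whether they differ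

The compounds shown leave open how other groups in the same place on the six-membered aromatic ring, such as fluoro, iodo, methyl or methoxy, would behave on either core. They also leave open whether the change would behave the same way on a further core, for example one carrying an amine or a longer chain in place of the part that differs between compound 1 and compound 3.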